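A few compounds are considered here, and "the series" means these few. Any claim that something is new, unique, unknown or untested is made for them only; others in the source may bear on it.

Measured so far in a functional assay on MDA-MB-231 cells (Homo sapiens) for antiproliferative activity, read by MTT assay, with a stated time of 24 h; a lower number here means a stronger inhibitor, a higher number a weaker inhibitor:
- compound 1 `COc1ccc(C(=O)/C=C/c2cc(-c3ccc(OC)c(OC)c3)n3nc(-c4ccccc4)cc3n2)cc1` gives 13900 nM
- compound 2 `COc1cc(-c2cc(C(=O)/C=C/c3ccc(C)cc3)nc3cc(-c4ccccc4)nn23)cc(OC)c1OC` gives 18600 nM
- compound 3 `COc1cc(-c2cc(/C=C/C(=O)c3ccc(C)cc3)nc3cc(-c4ccccc4)nn23)cc(OC)c1OC` gives 23900 nM

Compound 1 stands at the low end of these three numbers, but its gaps to compound 2 and to compound 3 are both within the usual scatter of repeated measurements, so the three compounds cannot be told apart on these data. Among the measured compounds shown here, the one measured pair that differs in a single place shows this directly: a 1.3-fold higher number from compound 2 to compound 3 (0.11 log units; within the scatter), a step that swaps the direction of the carbonyl-bearing linker and makes no difference beyond the scatter.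

Compound 4 `COc1ccc(-c2cc(/C=C/C(=O)c3ccc(C)c(C)c3)nc3cc(-c4ccccc4)nn23)cc1OC` is not yet measured. It differs from compound 1 in one place: 3,4-dimethylphenyl in place of 4-methoxyphenyl on a carbonyl carbon. For the measured compounds named here, none of the measured pairs changes the aromatic ring on the carbonyl carbon, so there is no step that bears directly on this change. Going by the values given here, the only single-place step in hand, from compound 2 to compound 3, is within the scatter, and the whole set spans a narrow range. On that basis no change beyond the scatter is expected, and compound 4 is estimated to give 14000 nM in this assay, with a range from 5000 nM to 40000 nM, which corresponds to an expected 1.0-fold higher number from compound 1 to compound 4 (0.00 log units; within the scatter).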

Compound 4, half-maximal inhibitory concentration: 11500 nM
Beside the measured number, compound 4's estimate is 1.2-fold (0.09 log units) above it; low and high end bracket the measured number.
By their numbers in this assay, from the lowest: compounds 4, 1, 2 and 3 (each within the scatter of the next, the first and the last beyond it).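

In this assay, among the compounds shown here, replacing 4-methoxyphenyl with 3,4-dimethylphenyl on the carbonyl carbon gives a 1.2-fold lower number from compound 1 to compound 4 (0.08 log units; within the scatter), the first direct reading of a change at this position. Both groups have the same heavy-atom count and one six-membered aromatic ring of carbon only, but the entering group has no oxygen and no hydrogen-bond acceptor, and in this one pair that exchange does not move the number beyond the scatter. No measurement shown here explains this outcome.

Going by these compounds, the two groups compared at this position are both carbon-only aromatic rings, so it remains open whether a pyridine ring, or a phenyl ring carrying an amine or a carboxylic acid, would shift the number beyond the scatter. A single pair also leaves open whether the same exchange would give a similar result on the other compounds shown, whose other groups differ from those of compound 1.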